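Swapping methyl for chloro on compound 1

The compounds below may be only part of what the source reports. "The series", "measured", "known", "first", "only" and "open" are said of these compounds alone.

compound 1 `Cc1ccc(-c2nc3ccccn3c2Sc2ccccc2)cc1` gives 86700 nM
compound 2 `Cc1ccc(-c2nc3ccc(C)cn3c2Sc2ccccc2)cc1` gives 65200 nM
compound 3 `Clc1ccc2nc(-c3ccccc3)c(Sc3ccccc3)n2c1` gives 29300 nM

All three were tested in a functional assay on HeLa cells (Homo sapiens) for inhibition, read by MTT assay, with a stated time of 48 h; a higher number here means a weaker inhibitor, a lower number a stronger inhibitor. Compound 1 shares the high end of these numbers with compound 2, while compound 3 lies lower, beyond the scatter from compound 1.

The next compound, compound 4 `Clc1ccc(-c2nc3ccccn3c2Sc2ccccc2)cc1`, turns the 4-methylphenyl of compound 1 into 4-chlorophenyl: chloro in place of methyl on an aromatic carbon. This is chloro in place of methyl on an aromatic carbon.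

Among the measured compounds shown here, no measured step makes this exact swap. The closest, a 1.3-fold lower number from compound 1 to compound 2 (0.12 log units; within the scatter), also involves a methyl, on an aromatic carbon at another place, and stays within the scatter. Compound 3 does carry a chloro and has a lower number than compound 1, but it differs in more than one place, so it is only a loose hint.

A small drop is therefore expected, an estimated 1.7-fold lower number from compound 1 to compound 4 (0.24 log units; within the scatter) in this assay, with no large move anticipated. The expected value for compound 4 is 50000 nM, with an estimated range of 22000 nM to 100000 nM.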

Compound 4, half-maximal inhibitory concentration: 62000 nM
Compound 4: the middle estimate sits 1.2-fold (0.09 log units) below what was measured; measured number inside the range.
By their numbers in this assay, from the lowest: compound 3; then compounds 4, 2 and 1 (each within the scatter of the next).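

In this assay, 4-chlorophenyl in place of 4-methylphenyl gives a 1.4-fold lower number from compound 1 to compound 4 (0.15 log units; within the scatter) and so leaves the number unchanged within the scatter. Among the compounds shown here, this is the first direct reading of this swap, and it shows that, at this place para to a large group, chloro and methyl cannot be told apart in this cell assay. Nothing measured here explains why the two groups read alike.

From the compounds shown here alone, what an amine or a carboxylic acid at this same place would do remains open, including whether either could move the number beyond the scatter from compound 1. Also open, going by these compounds, is whether the swap from methyl to chloro would read the same on the core of compound 2, which carries a second methyl elsewhere.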